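Aziridinyl quinone: hydroxymethoxyethyl in place of isopropyl

This account rests on a few compounds, and the source may have more. Where it says the series, first, only, none or still open, it means among the compounds named here.

Measured so far:
compound 1, `CC1=C(N2CC2)C(=O)C(C(C)C)=C(N2CC2)C1=O`, 4.69
compound 2, `CCC1=C(N2CC2)C(=O)C(CCOC(N)=O)=C(N2CC2)C1=O`, 4.88

Both compounds were tested in a functional assay on L1210 cells (Mus musculus), with a stated time of 1 days; a higher number here means a more potent compound, by a factor of ten per unit of this negative logarithm, a lower number a less potent compound. Compound 1 gives 4.69 and stands at the lower of the two numbers; the nearest, compound 2, gives 4.88, which lies within the scatter of compound 1, so the two cannot be told apart on these numbers.

Compound 3, `COC(CO)C1=C(N2CC2)C(=O)C(C)=C(N2CC2)C1=O`, has not yet been measured. It differs from compound 1 in one place: 2-hydroxy-1-methoxyethyl in place of isopropyl on a double-bonded ring carbon. Within the data shown here, no step between two measured compounds isolates this change, and compound 2 differs from compound 1 at two places at once, so it offers no direct comparison.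

With so little to go on, the author expects the step of a number 0.11 log units higher from compound 1 to compound 3 (within the scatter) to stay small, in either direction, and most likely within the scatter. The estimate for compound 3 in this assay is 4.8, with a range from 4.3 to 5.3.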

Compound 3, logarithm of the reciprocal of the active concentration, log(1/C): 5.27
For compound 3 the middle estimate is 0.47 log units below the measured one, within the range that was stated.
By their numbers in this assay, from the lowest: compounds 1 and 2 (each within the scatter of the next); then compound 3.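

In this assay, among these compounds, the position on the double-bonded ring carbon, next to the ring atom that bears an aziridin-1-yl group, proves sensitive to its substituent: the change gives a number 0.58 log units higher from compound 1 to compound 3 (beyond the scatter) and is the first single-place step in this set that can be read. The step is modest but lies beyond the scatter, and it shows that 2-hydroxy-1-methoxyethyl, with a hydrogen-bond donor and hydrogen-bond acceptors where isopropyl has neither, is not only accepted at this position but goes with a higher number. Nothing measured here bears on why the number rises, so the step stands as an observation only.

The hydroxy and methoxy parts of the new chain enter together, and the compounds shown leave open which of them goes with the step, or whether both are needed. They also leave open whether a simple hydroxymethyl or methoxymethyl group, a longer chain ending in hydroxy, or an amine in the same place would give a number like that of compound 3 or a different one.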